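The source may report more compounds than this note shows. Statements on the series, on what has been measured and on what is new or still open speak of the compounds shown alone.

Compound 1 `C=CS(=O)(=O)N1CCN(c2ncnc3sc(-c4ccccc4)cc23)CC1`: 21100 nM
Compound 2 `C=CS(=O)(=O)N1CCN(c2ncnc3ccc(-c4ccccc4)cc23)CC1`: 23400 nM

Both measured compounds carry the same vinylsulfonyl piperazine and an unsubstituted phenyl group, and differ only in the shared core. In a functional assay on MDA-MB-436 cells (Homo sapiens) for antiproliferative activity, read by MTT assay, with a stated time of 48 h (a lower number here means a stronger inhibitor, a higher number a weaker inhibitor), compound 1 gives 21100 nM. In this assay compound 2 gives 23400 nM. Among the compounds with values here, compound 1 holds the lower of the two numbers, but compound 2 lies within the scatter of it, so the two values cannot be told apart, and no step between them is given beyond what the two values show.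

The step followed here leads from compound 1 to compound 3 `C=CS(=O)(=O)N1CCN(c2ncnc3sc(-c4ccc(C#N)cc4)cc23)CC1`, which has not yet been measured in this assay. The change is cyano in place of hydrogen on an aromatic carbon. Within the data shown here, no step between measured compounds exists to calibrate it, so the size of the effect rests on the structural change alone. The expectation is for a step of modest size, if any, toward a lower number, not far beyond the scatter. The expected step is a 1.4-fold lower number from compound 1 to compound 3 (0.15 log units; within the scatter). Compound 3 is thus estimated at 15000 nM, within a range from 5000 nM to 45000 nM.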

Compound 3, half-maximal inhibitory concentration: 9170 nM
The estimate for compound 3 lay 1.6-fold (0.21 log units) above the measured number, within the range that was stated.
By their numbers in this assay, from the lowest: compound 3; then compounds 1 and 2 (each within the scatter of the next).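

The phenyl ring of compound 1 turns out to be a place where a change registers in this cell read-out: with cyano in place of hydrogen on an aromatic carbon, para to a large group, this assay gives a 2.3-fold lower number from compound 1 to compound 3 (0.36 log units; beyond the scatter). The earlier pair differed only in the shared core and showed no difference beyond the scatter, whereas this step, though modest, lies beyond it, and so it is the first change among the compounds shown that separates two values. It shows only that the number moves, and no measurement shown here says why phenyl to 4-cyanophenyl has this effect.

From the compounds shown here alone, it remains open whether another group at the same place, such as a methoxy group, an amine or a carboxylic acid, would move the number in the same direction or by a similar amount, and whether cyano at another place on the ring would do so. It is equally open whether the step from phenyl to 4-cyanophenyl carries over to the core of compound 2, since the single step shown rests on the core of compound 1 alone.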